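Cytotoxicity limit across the series, and compound 4

A few compounds are considered here, and "the series" means these few. Any claim that something is new, unique, unknown or untested is made for them only; others in the source may bear on it.

Measured in an ADME assay on HEK293 cells (Homo sapiens) for cytotoxicity, with a stated time of 72 h; a lower number here means that less compound is needed, a higher number that more compound is needed for the effect:
- compound 1 `C=C[C@@](C)(/C=C/c1ccc(O)c(/C=C/C(=O)OCC)c1)CCC=C(C)C`: > 36600 nM
- compound 2 `C=C[C@@](C)(/C=C/c1ccc(O)c(/C=C/c2ccc(F)cc2)c1)CCC=C(C)C`: > 36600 nM
- compound 3 `C=C[C@@](C)(/C=C/c1ccc(O)c(/C=C/c2ccc(Cl)c(Cl)c2)c1)CCC=C(C)C`: > 36600 nM

Each of these readings is a limit of the assay and not a number. Compound 3 stands at > 36600 nM, which is such a limit. The series as a whole shows (the limit of > 36600 nM in this assay, at which 3 of the 3 values shown sit).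

The next structure is compound 4 `C=C[C@@](C)(/C=C/c1ccc(O)c(/C=C/C=C/c2ccccc2)c1)CCC=C(C)C`, in which 2-phenylethenyl takes the place of 3,4-dichlorophenyl: 2-phenylethenyl in place of 3,4-dichlorophenyl on a double-bonded chain carbon bound to a double-bonded chain carbon.

Within the data shown here, three measured steps bear on this change, all at the same place: a step that the two limits leave unreadable from compound 1 to compound 2; a step that the two limits leave unreadable from compound 1 to compound 3; a step that the two limits leave unreadable from compound 2 to compound 3. None of them gives a size, so they offer no direction for the new group. Ethoxycarbonyl, 4-fluorophenyl and 3,4-dichlorophenyl all leave the reading at the limit, and compound 4 is expected to read the same way in this assay. The estimated change is a step that the limit leaves unreadable from compound 3 to compound 4, with no direction expected. Compound 4 is estimated at 40000 nM, with an expected range from 15000 nM to 80000 nM.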

Compound 4, half-maximal effective concentration: > 36600 nM
Compound 4 was reported as a limit; the forecaster's own chance of this, stated with the estimate: 80%; the middle value lies beyond the limit too.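

In this assay compound 4 gives > 36600 nM, which is a limit of the assay. The steps linking compound 4 to compound 1, compound 2 and compound 3 cannot be read. The compounds shown leave open whether the group at this place changes the cytotoxicity of the series at all, and the concentration at which any of them would reach the effect.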